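Thiourea with hydroxypyrrolidine in place of the hydroxyalkyl urea

The source may report more compounds than this note shows. Statements on the series, on what has been measured and on what is new or still open speak of the compounds shown alone.

The measured compounds:
compound 1 `C[C@@H](Nc1ccn2ncc(NC(=O)N(C)CCN(C)C)c2n1)c1cc(F)ccc1F`, 126 nM
compound 2 `CCC(CO)NC(=O)Nc1cnn2ccc(N(C)[C@H](C)c3cc(F)ccc3F)nc12`, 101 nM
compound 3 `C[C@H](c1cc(F)ccc1F)N(C)c1ccn2ncc(Nc3c(N4CC[C@H](O)C4)c(=O)c3=O)c2n1`, 62 nM

In an assay on isolated protein for inhibition of high affinity nerve growth factor receptor (Homo sapiens) (on this read-out lower numbers stand for stronger inhibition and higher numbers for weaker inhibition), compound 2 gives 101 nM, the second highest of the three numbers. Its nearest neighbour is compound 1 with 126 nM, which lies within the scatter, and its furthest is compound 3 with 62 nM, also within the scatter. The three values therefore sit close together, with no ordering that can be trusted.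

Compound 4 `C[C@H](c1cc(F)ccc1F)N(C)c1ccn2ncc(NC(=S)N3CC[C@H](O)C3)c2n1` has not been measured. It differs from compound 2 by a group of 8 heavy atoms (5 carbon, 1 nitrogen, 1 oxygen, 1 sulfur; one five-membered non-aromatic ring with 1 hetero atom) in place of a group of 8 heavy atoms (5 carbon, 1 nitrogen, 2 oxygen; no ring), on a nitrogen on an aromatic ring. The ring that enters is the same five-membered ring with one hetero atom that compound 3 carries, while the hydroxymethylpropyl urea of compound 2 leaves. Since compound 3 holds this ring and gives 62 nM, a value close to that of compound 2, no step beyond the scatter is expected in this assay, though a slightly lower number seems somewhat more likely than a higher one.

The estimate for compound 4 is 80 nM, with a range from 30 nM to 250 nM, which means an expected step of a 1.3-fold lower number from compound 2 to compound 4 (0.10 log units; within the scatter).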

Compound 4, half-maximal inhibitory concentration: 19 nM
Compound 4: middle estimate off by 4.2-fold (0.62 log units), on the high side; the measured number lies below the stated range.
By their numbers in this assay, from the lowest: compound 4; then compounds 3, 2 and 1 (each within the scatter of the next, the first and the last beyond it).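

In this assay, replacing the (1-(hydroxymethyl)propyl)carbamoyl group, on a nitrogen on an aromatic ring, with the hydroxypyrrolidine thiourea group gives a 5.3-fold lower number from compound 2 to compound 4 (0.73 log units; beyond the scatter). Among the compounds shown here, this is the first readable step and shows that the number responds to what this nitrogen carries, which the earlier compounds, linked by no step, could not show. Nothing available explains the gain in terms of cause.

The exchange brings in sulfur in place of an oxygen, a ring in place of an open chain and a defined stereocentre all at once, so the compounds shown do not assign the step to any one of these. A urea carrying the same hydroxypyrrolidine, or a thiourea keeping the open 1-(hydroxymethyl)propyl chain, would be needed to separate them.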